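Cytotoxicity notes on the amine-substituted series

The compounds below may be only part of what the source reports. "The series", "measured", "known", "first", "only" and "open" are said of these compounds alone.

Measured so far in a functional assay on HEL cells (Homo sapiens) for cytotoxicity, read by microscopy; a lower number here means that less compound is tolerated, a higher number that more compound is tolerated:
compound 1 `Cc1cn([C@@H]2O[C@H](CO[Si](C)(C)C(C)(C)C)[C@@]3(OS(=O)(=O)C=C3NCC(N)=O)[C@H]2O[Si](C)(C)C(C)(C)C)c(=O)n(C)c1=O`: 16000 nM
compound 2 `Cc1cn([C@@H]2O[C@H](CO[Si](C)(C)C(C)(C)C)[C@@]3(OS(=O)(=O)C=C3NCCC(=O)O)[C@H]2O[Si](C)(C)C(C)(C)C)c(=O)n(C)c1=O`: 80000 nM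
compound 3 `CCNC(=O)NC1=CS(=O)(=O)O[C@@]12[C@@H](CO[Si](C)(C)C(C)(C)C)O[C@@H](n1cc(C)c(=O)n(C)c1=O)[C@@H]2O[Si](C)(C)C(C)(C)C`: only a limit, >= 3200 nM

Compound 1 stands lowest of the two numbers; its nearest neighbour is compound 2, reached by a 5.0-fold higher number from compound 1 to compound 2 (0.70 log units; beyond the scatter). The step from compound 1 to compound 3, a step that the limit leaves unreadable from compound 1 to compound 3, cannot be sized because of the limit (the limit of >= 3200 nM in this assay, at which 1 of the 3 values shown sits).

Compound 4 `COC(=O)CCNC1=CS(=O)(=O)O[C@@]12[C@@H](CO[Si](C)(C)C(C)(C)C)O[C@@H](n1cc(C)c(=O)n(C)c1=O)[C@@H]2O[Si](C)(C)C(C)(C)C` differs from compound 1 by (methoxycarbonyl)methyl in place of carbamoyl on a saturated chain carbon bound to an amine nitrogen. Among the measured compounds shown here, the only readable step that bears on this position is a 5.0-fold higher number from compound 1 to compound 2 (0.70 log units; beyond the scatter), where the carbamoyl also gave way to a carbonyl-bearing chain; the ester in compound 4 sits between those two cases. A modest rise in this assay is therefore expected for compound 4, a 2.0-fold higher number from compound 1 to compound 4 (0.30 log units; within the scatter). The estimate for compound 4 is 32000 nM, with a range from 8000 nM to 100000 nM.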

Compound 4, minimum cytotoxic concentration: >= 400000 nM
Compound 4: a limit, no number (the forecaster's own chance of this, stated with the estimate: 20%); at least 12-fold (1.09 log units) between middle value and limit.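

In this assay, the place on a saturated chain carbon bound to an amine nitrogen tolerates more change than compound 2 alone indicated: (methoxycarbonyl)methyl in place of carbamoyl gives an at least 25-fold higher number from compound 1 to compound 4 (1.39 log units; beyond the scatter). The methyl on the oxygen next to a carbonyl group also counts on its own, with an at least 5.0-fold higher number from compound 2 to compound 4 (0.69 log units; beyond the scatter). The value of compound 4 is a limit: the limit of >= 400000 nM in this assay, at which 1 of the 4 values shown sits.

The step between compound 3 and compound 4 cannot be read. Going by these compounds, whether an ethyl ester or an amine on the same chain would give a number as high remains open.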